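Methoxy for Methyl on the Sulfonyl Ring

This account rests on a few compounds, and the source may have more. Where it says the series, first, only, none or still open, it means among the compounds named here.

Compound 1, `CN(C(=O)CCc1ccccc1)c1ccc2[nH]c(-c3n[nH]c4ccccc34)cc2n1`, in a functional assay on A549 cells (Homo sapiens) for antiproliferative activity, read by MTT assay, with a stated time of 72 h (on this read-out higher numbers stand for weaker inhibition and lower numbers for stronger inhibition), gives 18100 nM.
Compound 2, `CN(C(=O)c1ccc(F)cc1)c1ccc2[nH]c(-c3n[nH]c4ccccc34)cc2n1`, gives 9650 nM.
Compound 3, `Cc1ccc(S(=O)(=O)N(C)c2ccc3[nH]c(-c4n[nH]c5ccccc45)cc3n2)cc1`, gives 27100 nM.

Compound 3 shows the highest number of the three measured. Its separation from compound 1 is small, a 1.5-fold higher number from compound 1 to compound 3 (0.18 log units; within the scatter), while the step of a 2.8-fold higher number from compound 2 to compound 3 (0.45 log units; beyond the scatter) is modest but real.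

Among the measured compounds shown here, compound 4, `COc1ccc(S(=O)(=O)N(C)c2ccc3[nH]c(-c4n[nH]c5ccccc45)cc3n2)cc1`, keeps the shared core and the sulfonyl linkage of compound 3; the only change is methoxy in place of methyl on an aromatic carbon. For the measured compounds named here, none of the measured steps touches this part of the molecule: each swapped the whole group on the ring nitrogen rather than a substituent on its outer ring. Nothing measured therefore argues for a shift, and the expected change a 1.1-fold lower number from compound 3 to compound 4 (0.04 log units; within the scatter) is none beyond the scatter. For compound 4 the expected value is 25000 nM, with a range from 9000 nM to 70000 nM.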

Compound 4, half-maximal inhibitory concentration: 24300 nM
Compound 4: the middle estimate sits 1.0-fold (0.01 log units) above what was measured, within the range that was stated.
By their numbers in this assay, from the lowest: compounds 2, 1, 4 and 3 (each within the scatter of the next, the first and the last beyond it).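

Methoxy in place of methyl, on the outer ring of the sulfonyl group and para to a large group, is the first change here that alters a substituent on that ring rather than the whole group on the ring nitrogen. In this assay it gives a 1.1-fold lower number from compound 3 to compound 4 (0.05 log units; within the scatter), so adding one oxygen at this position produces no change that can be told from the scatter. Nothing available explains this result.

As far as these compounds go, whether an amine or a carboxylic acid at this position would move the number remains open. So does whether methoxy would behave the same way in place of the fluorine of compound 2.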